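This account rests on a few compounds, and the source may have more. Where it says the series, first, only, none or still open, it means among the compounds named here.

Measured compounds:
Compound 1, `COc1ccc2c(=O)c(/C=C/C(=O)Nc3cccc(C)c3)coc2c1`: 554000 nM
Compound 2, `COc1ccc(CNC(=O)/C=C/c2coc3cc(O)ccc3c2=O)cc1`: 718000 nM

In an ADME assay on HepG2 2.2.15 cells (Homo sapiens) for cytotoxicity, read by MTT assay, with stated times of 48 h and 9 days (a higher number here means that more compound is tolerated, a lower number that less compound is tolerated), compound 2 gives 718000 nM, the higher of the two numbers. Compound 1 gives 554000 nM, and the gap between the two lies within the scatter, so neither can be called better tolerated. Compound 3, `O=C(/C=C/c1coc2cc(O)ccc2c1=O)NCc1ccccc1`, has not been measured. It differs from compound 2 in one place: hydrogen in place of methoxy on an aromatic carbon. Among the compounds with values here, no measured pair shows what this change does, so no step beyond the scatter is expected in either direction. For compound 3 the estimate in this assay is 650000 nM, ranging from 350000 nM to 1200000 nM. This corresponds to an expected step of a 1.1-fold lower number from compound 2 to compound 3 (0.04 log units; within the scatter).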

Compound 3, half-maximal cytotoxic concentration: 436000 nM
For compound 3 the middle estimate is 1.5-fold (0.17 log units) above the measured one; low and high end bracket the measured number.
By their numbers in this assay, from the lowest: compounds 3, 1 and 2 (each within the scatter of the next).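

In this assay, within the data shown here, the change from 4-methoxyphenyl to phenyl gives a 1.6-fold lower number from compound 2 to compound 3 (0.22 log units; within the scatter) and is the first single change that can be read in this set. Methoxy on this aromatic carbon, para to a large group, can thus give way to hydrogen with no step beyond the scatter in tolerated concentration. No measurement here offers an explanation for this result. Going by these compounds, what a chlorine atom, an amine or a carboxylic acid would do at this same place stays open.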